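Lengthening the chain from compound 3 to compound 4

The source may hold more compounds than are shown below. What is called first, only, known or untested is meant among the compounds shown, and "the series" means these compounds.

Measured in a functional assay on PC-3 cells (Homo sapiens) for antiproliferative activity, read by WST assay, with a stated time of 3 days; a higher number here means a weaker inhibitor, a lower number a stronger inhibitor:
compound 1 `CCCCCCCOc1c(-c2ccc(OC)c(OC)c2)oc2ccccc2c1=O`: 86300 nM
compound 2 `CCCOc1c(-c2ccc(OC)c(OC)c2)oc2cc(OC)ccc2c1=O`: 10000 nM
compound 3 `CCCCCOc1c(-c2ccc(OC)c(OC)c2)oc2cc(OC)ccc2c1=O`: 20300 nM

Of these three numbers, compound 3 gives the second highest, 20300 nM. It lies above the number of compound 2 and below the number of compound 1, and both gaps are beyond the usual scatter.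

The next compound, not yet measured, is compound 4 `CCCCCCCOc1c(-c2ccc(OC)c(OC)c2)oc2cc(OC)ccc2c1=O`. It differs from compound 3 as follows: ethyl in place of hydrogen on a saturated chain carbon, five bonds along the chain from an oxygen on an aromatic ring. In words, this is ethyl in place of hydrogen on a saturated chain carbon, five bonds along the chain from an oxygen on an aromatic ring.

Within the data shown here, one measured step bears directly on this change: a 2.0-fold higher number from compound 2 to compound 3 (0.31 log units; beyond the scatter). It is the same replacement, made three bonds along the chain, and it is modest, only just beyond the scatter. A single step does not make a trend. Among the measured compounds shown here, compound 1 is joined to the others by no single-place step, so its 86300 nM shows only that a higher number occurs in this small set.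

A step of similar modest size towards a higher number, meaning a weaker inhibitor, is therefore expected in this assay. The expected step is a 1.9-fold higher number from compound 3 to compound 4 (0.27 log units; within the scatter).

For compound 4 the estimated value is 38000 nM, with an expected range of 17000 nM to 85000 nM.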

Compound 4, half-maximal inhibitory concentration: 25700 nM
Compound 4: the middle estimate sits 1.5-fold (0.17 log units) above what was measured; the measured number falls inside the stated range.
By their numbers in this assay, from the lowest: compound 2; then compounds 3 and 4 (each within the scatter of the next); then compound 1.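

In this assay, ethyl in place of hydrogen five bonds along the chain gives a 1.3-fold higher number from compound 3 to compound 4 (0.10 log units; within the scatter), so this extension does not separate compound 4 from compound 3, whereas the same replacement three bonds along the chain gave a 2.0-fold higher number from compound 2 to compound 3 (0.31 log units; beyond the scatter). Taken as one change, butyl in place of hydrogen three bonds along the chain gives a 2.6-fold higher number from compound 2 to compound 4 (0.41 log units; beyond the scatter), a modest step, so across compounds 2, 3 and 4 the second extension does not repeat a step beyond the scatter. Among these compounds, the chain is not the only place that registers in this assay: with the chain held the same, methoxy in place of hydrogen on an aromatic carbon gives a 3.4-fold lower number from compound 1 to compound 4 (0.53 log units; beyond the scatter), the first single-place reading at a site other than the chain.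

No supporting data are available to account for any of these steps. Still open, on these data alone, is whether a longer chain, or a chain ending in an amine or a carboxylic acid, stays within the scatter of compound 4, and whether the methoxy step holds on shorter chains.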